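Thioether aryl exchange on the nucleoside series

The source may hold more compounds than are shown below. What is called first, only, known or untested is meant among the compounds shown, and "the series" means these compounds.

Of the compounds shown here, two have been measured in an assay on isolated protein for binding affinity to Equilibrative nucleoside transporter 1 (Homo sapiens); on this read-out lower numbers stand for stronger inhibition and higher numbers for weaker inhibition. Compound 1 `OC[C@H]1O[C@@H](n2cnc3c(NCc4ccco4)ncnc32)[C@H](O)[C@@H]1O` gives 36300 nM in this assay. Compound 2 `Cc1cc(C)c(SCc2ncnc3c2ncn3[C@@H]2O[C@H](CO)[C@@H](O)[C@H]2O)c(C)c1` gives 33100 nM in this assay. Among the measured compounds shown here, the two numbers sit within the usual scatter of each other, so nothing separates compound 2 from compound 1 on this read-out; both stand at the weak end of the scale, and no step between them can be stated.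

The next compound, compound 3 `OC[C@H]1O[C@@H](n2cnc3c(CSc4ccccc4F)ncnc32)[C@H](O)[C@@H]1O`, differs from compound 2 in one place: 2-fluorophenyl in place of 2,4,6-trimethylphenyl on a sulfur. For the measured compounds named here, no measured step of this kind exists, so the expectation rests only on the two weak numbers in hand. The step from compound 2 to compound 3 is expected to be small, a 1.1-fold lower number from compound 2 to compound 3 (0.04 log units; within the scatter), with no clear direction beyond the scatter. Compound 3 is estimated at 30000 nM in this assay, with a range from 9000 nM to 100000 nM.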

Compound 3, half-maximal inhibitory concentration: 355 nM
For compound 3 the middle estimate is 85-fold (1.93 log units) above the measured one; the whole stated range lies above it.
By their numbers in this assay, from the lowest: compound 3; then compounds 2 and 1 (each within the scatter of the next).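

In this assay, among the compounds shown here, the group on this sulfur is the first place where a single exchange clearly moves the read-out: 2-fluorophenyl in place of 2,4,6-trimethylphenyl gives a 93-fold lower number from compound 2 to compound 3 (1.97 log units; beyond the scatter), so the position is not indifferent to the aryl group it carries, even though compound 1 and compound 2 stood together at the weak end. The wider exchange on the aromatic carbon, ((2-fluorophenyl)sulfanyl)methyl in place of ((furan-2-yl)methyl)amino, gives a 100-fold lower number from compound 1 to compound 3 (2.01 log units; beyond the scatter), which leaves compound 3 as the strongest of the three and shows that the shared core can reach a far lower number with the right substituent at this point. The data at hand offer no explanation for the size of this gain.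

The compounds shown do not separate the arrival of the fluorine from the departure of the three methyl groups, as the single exchange does both at once, and an unsubstituted phenyl or a 2-chlorophenyl on the sulfur would bear on that. They also leave open how much the sulfur itself contributes, a question that an oxygen or a methylene in its place would address.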